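Cytotoxicity of Compound 3, a Triazolyl Analogue of Compound 1

This account rests on a few compounds, and the source may have more. Where it says the series, first, only, none or still open, it means among the compounds named here.

Compound 1 `Cc1nc2cc(C(=O)NCc3ccc(F)cc3)nn2c(-c2cc(F)c3c(c2C)CCCO3)c1[C@H](OC(C)(C)C)C(=O)O` gives > 40000 nM in an ADME assay on MT2 cells (Homo sapiens) for cytotoxicity; on this read-out lower numbers stand for higher toxicity in this test and higher numbers for lower toxicity in this test.
Compound 2 `COc1cc(CNC(=O)c2cc3nc(C)c([C@H](OC(C)(C)C)C(=O)O)c(-c4cc(F)c5c(c4C)CCCO5)n3n2)ccc1F` gives > 20000 nM in this assay.

Both of these values are limits of this assay and not numbers. Compound 1 stands at one limit. Compound 2 stands at another limit. Within the data shown here, the one measured step, a step that the two limits leave unreadable from compound 1 to compound 2, is therefore unreadable in size or direction because the limit of > 40000 nM in this assay, at which 1 of the 2 values shown sits, and the limit of > 20000 nM in this assay, at which 1 of the 2 values shown sits, bracket the pair without giving either a value.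

Compound 3 `Cc1nc2cc(C(=O)NCc3ccc(F)cc3-n3cncn3)nn2c(-c2cc(F)c3c(c2C)CCCO3)c1[C@H](OC(C)(C)C)C(=O)O` has not yet been measured in this assay. It differs from compound 1 by 1H-1,2,4-triazol-1-yl in place of hydrogen on an aromatic carbon. Among the measured compounds shown here, no measured step of this kind exists, and the only step available gives no readable size. What can be said is that compound 1 shows no measurable toxicity within the tested range, and compound 2 likewise.

On that basis, compound 3 is expected to behave as compound 1 does, with a step of a number no higher from compound 1 to compound 3 (the limit leaves the size open) that is not expected to exceed the scatter. Compound 3 is therefore estimated at 40000 nM in this assay, in a range from 15000 nM to 100000 nM, most likely reported again only as a limit.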

Compound 3, half-maximal cytotoxic concentration: > 40000 nM
Compound 3: no number, only a limit (the forecaster's own chance of this, stated with the estimate: 80%); the middle value sits exactly at the limit.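

Compound 3 gives > 40000 nM in this assay, which is a limit of the assay and not a number. Among these compounds, no step from compound 1 or compound 2 to compound 3 can be read. The compounds shown leave open whether the 1H-1,2,4-triazol-1-yl group changes the read-out of this assay at all, and in which direction.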